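Phenyl to indolyl swap in a motilin receptor macrocycle series

The source may hold more compounds than are shown below. What is called first, only, known or untested is meant among the compounds shown, and "the series" means these compounds.

Measured so far:
- compound 1 `CCC[C@@H]1NC(=O)[C@@H](C(C)C)NC(=O)[C@@H](Cc2ccc(O)cc2)NCCCc2ccccc2/C=C\CCNC1=O`: 7300 nM
- compound 2 `CCC[C@@H]1NC(=O)[C@@H](C(C)C)NC(=O)[C@@H](Cc2ccccc2)NCCOc2ccccc2CCCNC1=O`: 57 nM

Among the compounds with values here, in an assay on isolated protein for displacement of a labelled ligand from Motilin receptor (Homo sapiens) (on this read-out lower numbers stand for stronger inhibition and higher numbers for weaker inhibition), compound 2 gives 57 nM, the lower of the two numbers so far; compound 1 gives 7300 nM, a gap well beyond the scatter. Compound 3 `CCC[C@@H]1NC(=O)[C@@H](C(C)C)NC(=O)[C@@H](Cc2c[nH]c3ccccc23)NCCOc2ccccc2CCCNC1=O` keeps the core of compound 2 and differs only in one place: 1H-indol-3-yl in place of phenyl on a saturated chain carbon bound to a saturated ring carbon. Within the data shown here, no measured pair isolates this change, so the expectation rests on compound 2 alone. The step from compound 2 to compound 3 in this assay is expected to be small, a 1.4-fold higher number from compound 2 to compound 3 (0.15 log units; within the scatter), with no clear direction beyond the scatter. Compound 3 is therefore estimated at 80 nM, within 20 nM to 400 nM.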

Compound 3, inhibition constant: 255 nM
The estimate for compound 3 lay 3.2-fold (0.50 log units) below the measured number; low and high end bracket the measured number.
By their numbers in this assay, from the lowest: compound 2; then compound 3; then compound 1.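

In this assay, 1H-indol-3-yl in place of phenyl on a saturated chain carbon bound to a saturated ring carbon gives a 4.5-fold higher number from compound 2 to compound 3 (0.65 log units; beyond the scatter), a modest step beyond the scatter. This position therefore registers the swap, and the benzyl of compound 2 remains ahead of the (1H-indol-3-yl)methyl of compound 3. Nothing on hand bears on the reason for this step. The compounds shown leave open whether the step follows the added five-membered ring or its hydrogen-bond donor. A 2-naphthylmethyl group, built of carbon only, would separate these two.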